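The source may hold more compounds than are shown below. What is called first, only, known or untested is meant among the compounds shown, and "the series" means these compounds.

Measured in an ADME assay on LLC-MK2 cells (Macaca mulatta) for cytotoxicity, read by spectrophotometry and crystal violet staining, with a stated time of 4 days; a lower number here means that less compound is tolerated, a higher number that more compound is tolerated:
- compound 1 `CC(C)n1ncc2c(C(=O)Nc3ncccn3)cc(-c3ccsc3)nc21`: 50000 nM
- compound 2 `CC(C)n1ncc2c(C(=O)Nc3ccncc3)cc(-c3cccs3)nc21`: 6300 nM
- compound 3 `CC(C)n1ncc2c(C(=O)Nc3ccncn3)cc(-c3ccsc3)nc21`: > 200000 nM

The entry for compound 3 is a limit of the assay and not a number.

Compound 2 stands lowest of the two numbers, beyond the scatter from compound 1. The next change gives compound 4 `CC(C)n1ncc2c(C(=O)Nc3cncnc3)cc(-c3cccs3)nc21`: pyrimidin-5-yl in place of pyridin-4-yl on an amide-type nitrogen. Going by the values given here, no measured step makes this exact swap, and compound 1 and compound 3 also differ from compound 2 elsewhere. The nearest evidence is an at least 4.0-fold higher number from compound 1 to compound 3 (0.60 log units; beyond the scatter), with pyrimidin-4-yl in place of pyrimidin-2-yl. Both of these pyrimidine compounds stand above compound 2, so a rise beyond the scatter is expected in this assay, with wide uncertainty. The expected change is a 4.0-fold higher number from compound 2 to compound 4 (0.60 log units; beyond the scatter). Compound 4 is estimated at 25000 nM, with an expected range of 7000 nM to 120000 nM.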

Compound 4, half-maximal cytotoxic concentration: 20000 nM
The estimate for compound 4 lay 1.3-fold (0.10 log units) above the measured number, and the stated range covers the measured number.
By their numbers in this assay, from the lowest: compound 2; then compound 4; then compound 1. At a limit, above all of these: compound 3.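

Pyrimidin-5-yl in place of pyridin-4-yl on the amide-type nitrogen gives, in this assay, a 3.2-fold higher number from compound 2 to compound 4 (0.50 log units; beyond the scatter). This step shows that the group on this nitrogen alters the tolerated concentration when the rest of compound 2 is held unchanged, and it starts from pyridin-4-yl, not from a pyrimidine. The step is modest, and compound 4 gives a real number, not a limit.

The compounds shown leave open how a morpholine or a carboxylic acid would read on this nitrogen's ring. The upper end of the scale also stays unresolved: the limit of > 200000 nM in this assay, at which 1 of the 4 values shown sits.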